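Reverting the Linker Change: An Expected Loss of Growth Inhibition

This account rests on a few compounds, and the source may have more. Where it says the series, first, only, none or still open, it means among the compounds named here.

Compound 1, `COc1cc(-c2nn(-c3cccc(NC(=O)c4cccc(C(F)(F)F)c4)c3)cc2-c2ccncc2)ccc1Cl`: in a functional assay on CAKI-1 cells (Homo sapiens) for inhibition, read by sulforhodamine B assay, with a stated time of 48 h (on this read-out higher numbers stand for weaker inhibition of growth and lower numbers for stronger inhibition of growth), compound 1 gives only a limit, > 50000 nM.
Compound 2, `COc1cc(-c2nn(-c3cccc(NC(=O)Nc4cccc(C(F)(F)F)c4)c3)cc2-c2ccncc2)ccc1Cl`: in this assay compound 2 gives 3510 nM.

Compound 2 therefore holds the only real number shown; the other value is the limit of > 50000 nM in this assay, at which 1 of the 2 values shown sits. Compound 3, `COc1cc(-c2nn(-c3cccc(NC(=O)c4ccc(Cl)c(C(F)(F)F)c4)c3)cc2-c2ccncc2)ccc1Cl`, differs from compound 2 by 4-chloro-3-(trifluoromethyl)phenyl in place of (3-(trifluoromethyl)phenyl)amino on a carbonyl carbon. Among the compounds with values here, the one measured step bears on this directly but in the opposite sense: an at least 14-fold lower number from compound 1 to compound 2 (1.15 log units; beyond the scatter). Reversing that change is expected to undo most of the gain, so a large rise is expected, a 13-fold higher number from compound 2 to compound 3 (1.11 log units; beyond the scatter). For compound 3 the estimate in this assay is 45000 nM, between 12000 nM and 200000 nM, with a real chance that only a limit is reported.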

Compound 3, concentration for total growth inhibition: > 32500 nM
Compound 3: only a limit was reported; the forecaster's own chance of this, stated with the estimate: 55%; the middle value is on the limit's open side.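

In this assay, setting 4-chloro-3-(trifluoromethyl)phenyl on the carbonyl carbon in place of (3-(trifluoromethyl)phenyl)amino gives an at least 9.2-fold higher number from compound 2 to compound 3 (0.96 log units; beyond the scatter), so a second compound lacking that amino link also loses growth inhibition, this time with chloro on the ring. Compound 3 gives a limit and not a number: the limit of > 32500 nM in this assay, at which 1 of the 3 values shown sits. The step from chloro in place of hydrogen cannot be read, as both of its ends are limits.

As far as these compounds go, it remains open whether a methylene or an ether oxygen in place of the amino nitrogen would keep the growth inhibition of compound 2.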